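Swapping Phenyl for Methoxy on a Weak Inhibitor

A few compounds are considered here, and "the series" means these few. Any claim that something is new, unique, unknown or untested is made for them only; others in the source may bear on it.

Of the compounds shown here, two have been measured in a functional assay for inhibition, with Homo sapiens as the target; a lower number here means a stronger inhibitor, a higher number a weaker inhibitor. Compound 1, with structure `C=CCn1ncc2cnc(Cc3ccccc3)n2c1=O`, reaches only the limit of the assay: in this assay compound 1 gives > 48000 nM, which is a limit and not a measured number. Compound 2, with structure `CCOC(=O)CSc1nncc2cnc(C)n12`, shares the core but carries other groups on it; in this assay compound 2 gives 52000 nM. Both results sit at the weak end, and compound 1 stands at the limit itself, as one of the two values does (the limit of > 48000 nM in this assay, at which 1 of the 2 values shown sits).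

Compound 3, with structure `C=CCn1ncc2cnc(COC)n2c1=O`, differs from compound 1 in one place: methoxy in place of phenyl on a saturated chain carbon bound to an aromatic carbon. Going by the values given here, no measured pair shows what such a swap does here, and since compound 1 is known only as a limit, the starting point is itself uncertain. A move beyond the usual scatter in either direction would not be surprising, but the weak results of both measured compounds give no ground to expect a large gain. The expected value for compound 3 is 60000 nM, with a likely range from 20000 nM to 200000 nM. The step that the limit leaves unreadable from compound 1 to compound 3 is expected to be small.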

Compound 3, half-maximal inhibitory concentration: > 48000 nM
Compound 3 gave a limit, no number (the forecaster's own chance of this, stated with the estimate: 70%); the middle value is on the limit's open side.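

In this assay compound 3 gives > 48000 nM, which is a limit and not a number. Compound 1 also stands at a limit, so no step from compound 1 to compound 3 can be read: the limit of > 48000 nM in this assay, at which 2 of the 3 values shown sit.

From the compounds shown here alone, whether methoxy in place of phenyl changes inhibition at all, and in which direction, stays open.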